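Swapping Chloro for Methylsulfanyl on a Dopamine Receptor Agonist

A few compounds are considered here, and "the series" means these few. Any claim that something is new, unique, unknown or untested is made for them only; others in the source may bear on it.

For the measured compounds named here, compound 2 `O=C(CN1CCC(c2cccc[n+]2[O-])CC1)Nc1cccc(Cl)c1` gives 76% in a functional assay on HEK293 cells for agonist activity at D(4) dopamine receptor (Homo sapiens), read by FLIPR (on this read-out lower numbers stand for smaller maximal responses and higher numbers for larger maximal responses), the higher of the two numbers measured so far. Going by the values given here, its only neighbour, compound 1 `O=C(CN1CCC(c2cccc[n+]2[O-])CC1)Nc1cc(Cl)cc(Cl)c1`, gives 68%; the step of a number 8 percentage points higher from compound 1 to compound 2 (within the scatter) is within the scatter. Compound 3 `CSc1cccc(NC(=O)CN2CCC(c3cccc[n+]3[O-])CC2)c1` differs from compound 2 by methylsulfanyl in place of chloro on an aromatic carbon. Among the compounds with values here, no measured step covers this exchange; the one step available, the loss of a chloro, changed little. The step of a number 2 percentage points lower from compound 2 to compound 3 (within the scatter) is therefore expected to stay within the scatter. Compound 3 is estimated at 74%, with a range from 58% to 90%.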

Compound 3, largest response reached (reported as efficacy), in percent of the reference or control that the assay uses: 56%
For compound 3 the middle estimate is 18 percentage points above the measured one, and the stated range ends above it.
By their numbers in this assay, from the lowest: compound 3; then compounds 1 and 2 (each within the scatter of the next).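

Replacing chloro with methylsulfanyl on the aromatic carbon gives a number 20 percentage points lower from compound 2 to compound 3 (beyond the scatter) in this assay and so shows that this position can respond to the group placed on it, which a number 8 percentage points higher from compound 1 to compound 2 (within the scatter) did not show. The same lower response appears with 3-(methylsulfanyl)phenyl in place of 3,5-dichlorophenyl, as a number 12 percentage points lower from compound 1 to compound 3 (beyond the scatter) shows. As far as these compounds go, whether an amine, a methoxy group or a longer thioether chain at this position would give a larger or smaller maximal response remains open. No available evidence accounts for the lower response of compound 3.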